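A few compounds are considered here, and "the series" means these few. Any claim that something is new, unique, unknown or untested is made for them only; others in the source may bear on it.

Compound 2 `CCCNC(=O)[C@H]1C[C@@H]2CNC[C@@H](C2)C1` gives 6 nM in an assay on SHEP1 cells for displacement of a labelled ligand from Neuronal acetylcholine receptor; alpha4/beta2 (Homo sapiens), read by scintillation counting, with a stated time of 2 h (a lower number here means a stronger inhibitor, a higher number a weaker inhibitor), and so holds the higher of the two numbers measured, with compound 1 `CNC(=O)[C@H]1C[C@@H]2CNC[C@@H](C2)C1` at 1.9 nM beside it. Compound 3 `CC(C)NC(=O)[C@H]1C[C@@H]2CNC[C@@H](C2)C1` differs from compound 2 by isopropyl in place of propyl on an amide-type nitrogen. Going by the values given here, the one step measured so far, a 3.2-fold higher number from compound 1 to compound 2 (0.50 log units; beyond the scatter), concerns lengthening the chain rather than branching it, so it bears on this change only loosely. Compound 3 is therefore expected to lie near compound 2, with a step of a 1.3-fold higher number from compound 2 to compound 3 (0.12 log units; within the scatter) that may not clear the scatter. The estimate for compound 3 in this assay is 8 nM, between 3 nM and 25 nM.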

Compound 3, inhibition constant: 23 nM
Compound 3: the middle estimate sits 2.9-fold (0.46 log units) below what was measured; low and high end bracket the measured number.
By their numbers in this assay, from the lowest: compound 1; then compound 2; then compound 3.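

Joining the same three carbons as isopropyl rather than propyl on an amide-type nitrogen gives, in this assay, a 3.8-fold higher number from compound 2 to compound 3 (0.58 log units; beyond the scatter) and so moves the number beyond the scatter with no change in atoms. The count of carbons alone therefore does not set the number at this position, and the step to isopropyl from the methyl amide is larger still, with a 12-fold higher number from compound 1 to compound 3 (1.08 log units; beyond the scatter) on the same nitrogen. No measurement offered here accounts for this difference between the chains. The compounds shown leave open how a longer chain such as butyl, a tert-butyl group or a cyclopropyl group would stand on this nitrogen. They also leave open the place of the plain amide, with hydrogen in place of methyl.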